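From a Hydrazide to a Bicyclic Amide in Cytotoxicity Testing

A few compounds are considered here, and "the series" means these few. Any claim that something is new, unique, unknown or untested is made for them only; others in the source may bear on it.

compound 1 `NNC(=O)c1cc(-c2ccccc2)nc2ccccc12` — > 300000 nM
compound 2 `CC(C)Oc1cc(C(=O)NC2CCN(C)CC2)c2ccccc2n1` — 101000 nM
compound 3 `O=C(NCCCn1ccnc1)c1cc(-c2cccs2)nc2ccccc12` — 55700 nM

Of the compounds shown here, three have been measured in an ADME assay on RD cells (Homo sapiens) for cytotoxicity, read by neutral red uptake, with a stated time of 3 days; on this read-out lower numbers stand for higher toxicity in this test and higher numbers for lower toxicity in this test. Compound 1 gives only a limit of the assay, > 300000 nM, and so stands at the limit of > 300000 nM in this assay, at which 1 of the 3 values shown sits. Compound 2 gives 101000 nM in this assay. Compound 3 gives 55700 nM in this assay. Compound 4 `O=C(NC1CN2CCC1CC2)c1cc(-c2ccccc2)nc2ccccc12` has not yet been measured. It differs from compound 1 in one place: a group of 8 heavy atoms (7 carbon, 1 nitrogen; 2 six-membered non-aromatic rings with 1 hetero atom each) in place of one nitrogen atom, on an amide-type nitrogen. Among the measured compounds shown here, no step between two measured compounds is available, so the size of this step can only be expected. Given compound 2 at 101000 nM and compound 3 at 55700 nM, compound 4 is expected to move modestly toward higher toxicity, an at least 3.0-fold lower number from compound 1 to compound 4 (0.47 log units; beyond the scatter). Compound 4 is therefore estimated at 100000 nM, within 30000 nM to 300000 nM.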

Compound 4, half-maximal cytotoxic concentration: 46500 nM
Estimate against measurement, compound 4: 2.2-fold (0.33 log units) above; the range from low to high includes it.
By their numbers in this assay, from the lowest: compounds 4, 3 and 2 (each within the scatter of the next, the first and the last beyond it). At a limit, above all of these: compound 1.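

In this assay, putting the group with 2 six-membered non-aromatic rings in place of the amino group, on the amide-type nitrogen, gives an at least 6.4-fold lower number from compound 1 to compound 4 (0.80 log units; beyond the scatter). Among the compounds shown here, compounds 2 and 3 could not show this, as neither differs from compound 1 in one place only, so this change on the shared core is the first that can be read on its own. How large the step really is stays open because compound 1 gives only a limit: the limit of > 300000 nM in this assay, at which 1 of the 4 values shown sits.

The compounds shown leave open what a plain methyl group or a longer chain ending in a dimethylamino group would do on this nitrogen.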